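Benzyl in place of phenyl on the anilino nitrogen

This account rests on a few compounds, and the source may have more. Where it says the series, first, only, none or still open, it means among the compounds named here.

Compound 1, `N#Cc1c(Nc2ccccc2)c(Cl)c2nc(N)nc(N)c2c1F`. In a functional assay on A549 cells (Homo sapiens) for cytotoxicity, read by MTT assay (a lower number here means a stronger inhibitor, a higher number a weaker inhibitor), compound 1 gives > 1000 ug/mL, which is a limit of the assay rather than a number.
Compound 2, `N#Cc1c(Nc2ccccc2)c(F)c2nc(N)nc(N)c2c1F`. In this assay compound 2 gives > 1000 ug/mL, again a limit of the assay.
Compound 3, `N#Cc1c(Nc2ccc(Cl)cc2)c(F)c2nc(N)nc(N)c2c1F`. In this assay compound 3 gives 115 ug/mL.

Compound 1 thus stands at the upper end of what this assay can report, and it is not alone there: the limit of > 1000 ug/mL in this assay, at which 2 of the 3 values shown sit. Only compound 3 gives a number at all.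

Two steps have been measured. From compound 1 to compound 2 there is a step that the two limits leave unreadable from compound 1 to compound 2. From compound 2 to compound 3 there is an at least 8.6-fold lower number from compound 2 to compound 3 (0.93 log units; beyond the scatter).

Compound 4, `N#Cc1c(NCc2ccccc2)c(Cl)c2nc(N)nc(N)c2c1F`, differs from compound 1 by benzyl in place of phenyl on a nitrogen on an aromatic ring. Neither measured step touches this place: the first changes a halogen on the shared core, the second adds chloro to the phenyl ring. The measured steps therefore give no guide to the size or direction of the change for compound 4, and the scatter is the only yardstick.

The estimate for compound 4 is an at least 1.1-fold lower number from compound 1 to compound 4 (0.04 log units; that floor lies within the scatter), with the number most likely remaining at the limit. Compound 4 is expected at 900 ug/mL, within a range from 250 ug/mL to 3000 ug/mL.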

Compound 4, half-maximal inhibitory concentration: 34.1 ug/mL
Compound 4: middle estimate off by 26-fold (1.42 log units), on the high side; measured number below the stated range.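

The nitrogen on the aromatic ring proves to be a place that responds in this assay: the move from anilino to benzylamino gives an at least 29-fold lower number from compound 1 to compound 4 (1.46 log units; beyond the scatter), and this is the first change at this place among the compounds shown. Compound 1 gives > 1000 ug/mL, which is a limit of the assay and not a number, so the step has a floor but no measured full size, and the same ceiling applies to more than one compound: the limit of > 1000 ug/mL in this assay, at which 2 of the 4 values shown sit. The two groups are alike in what can be counted on them, each with one six-membered aromatic ring of carbon only and with no hydrogen-bond donors or acceptors, and they differ in heavy atoms, 6 for phenyl and 7 for benzyl.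

The compounds shown leave open whether benzyl in place of phenyl gives a comparable step on the core of compound 2, or with chloro on the ring as in compound 3. They also leave open what a longer chain such as phenethyl, or a methyl on the same nitrogen, would do at this place.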